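The source may hold more compounds than are shown below. What is called first, only, known or untested is meant among the compounds shown, and "the series" means these compounds.

Working notes on the series. Compound 1 `NS(=O)(=O)c1ccc2nc(-c3ccc(-c4ccccc4F)cc3)[nH]c2c1` in an assay on isolated protein for inhibition of stearoyl-CoA desaturase 5 (Homo sapiens) (a higher number here means a weaker inhibitor, a lower number a stronger inhibitor), gives > 20000 nM, which is a limit of the assay. Compound 2 `CCS(=O)(=O)c1ccc2nc(-c3ccc(-c4ccccc4F)cc3)[nH]c2c1` gives > 20000 nM, also a limit. The step that the two limits leave unreadable from compound 1 to compound 2 is therefore not readable. Compound 3 `CS(=O)(=O)c1ccc2nc(-c3ccc(-c4ccccc4)cc3)[nH]c2c1` gives > 10000 nM, again a limit. Among the compounds with values here, compound 3 thus stands at the limit of > 10000 nM in this assay, at which 1 of the 3 values shown sits, while the other two compounds sit at the limit of > 20000 nM in this assay, at which 2 of the 3 values shown sit, so no measured step in this set can be read. Compound 4 `CS(=O)(=O)c1ccc2nc(-c3ccc(-c4cccc(F)c4)cc3)[nH]c2c1` differs from compound 3 by fluoro in place of hydrogen on an aromatic carbon. Within the data shown here, no measured step bears on this change. With every shown value a limit, compound 4 is expected to remain weak, and the step that the limit leaves unreadable from compound 3 to compound 4 is expected to be none beyond the scatter. The estimate for compound 4 is 15000 nM, within 5000 nM to 50000 nM, most likely reported only as a limit.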

Compound 4, half-maximal inhibitory concentration: > 20000 nM
Compound 4: no number, only a limit; the forecaster's own chance of this, stated with the estimate: 70%; middle value at least 1.3-fold (0.12 log units) away from the limit.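

Within the data shown here, compound 3 and compound 4 both sit at limits of the assay, so no step between them can be read. With every value shown a limit, the compounds shown leave open whether fluoro in place of hydrogen changes inhibition at all.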